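Nitro for bromo on a triazolethione-thiazole series in mice

This account rests on a few compounds, and the source may have more. Where it says the series, first, only, none or still open, it means among the compounds named here.

Measured so far:
compound 1, `COc1ccccc1-n1c(Nc2nc(-c3ccc([N+](=O)[O-])cc3)cs2)n[nH]c1=S`, 100 mg/kg
compound 2, `COc1ccccc1-n1c(Nc2nc(-c3ccc(Br)cc3)cs2)n[nH]c1=S`, 300 mg/kg
compound 3, `Cc1ccccc1-n1c(Nc2nc(-c3ccc(Br)cc3)cs2)n[nH]c1=S`, 30 mg/kg

All three were tested in a functional assay on the whole organism (strain Swiss albino) for inhibition, with Mus musculus as the target, with a stated time of 4 h; on this read-out higher numbers stand for an effect only at larger amounts of compound and lower numbers for an effect already at smaller amounts. Compound 2 serves as the reference point. The change to compound 1 is nitro in place of bromo on an aromatic carbon, and it gave a 3.0-fold lower number from compound 2 to compound 1 (0.48 log units; beyond the scatter). The change to compound 3 is methyl in place of methoxy on an aromatic carbon, and it gave a 10-fold lower number from compound 2 to compound 3 (1.00 log units; beyond the scatter), leaving compound 3 with the lowest number of the three.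

Compound 4, `Cc1ccccc1-n1c(Nc2nc(-c3ccc([N+](=O)[O-])cc3)cs2)n[nH]c1=S`, has not yet been measured. It carries the same change as compound 1 carried, now on the core of compound 3: nitro in place of bromo on an aromatic carbon. Because that same change gave a 3.0-fold lower number from compound 2 to compound 1 (0.48 log units; beyond the scatter), a step of similar size is expected here, a 3.0-fold lower number from compound 3 to compound 4 (0.48 log units; beyond the scatter), resting on a single earlier example only. Compound 4 is therefore estimated at 10 mg/kg, between 5 mg/kg and 30 mg/kg.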

Compound 4, minimum effective dose: 100 mg/kg
Estimate against measurement, compound 4: 10-fold (1.00 log units) below; measured number above the stated range.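

Nitro in place of bromo gave a 3.3-fold higher number from compound 3 to compound 4 (0.52 log units; beyond the scatter), so the change did not carry over from the core of compound 2 to the core of compound 3: the same change on two cores in this assay, a 3.0-fold lower number (0.48 log units; beyond the scatter) from compound 2 to compound 1 and a 3.3-fold higher number (0.52 log units; beyond the scatter) from compound 3 to compound 4, 10-fold (1.00 log units) apart, beyond the scatter of two such steps
Methyl in place of methoxy also depended on its surroundings, giving no change at the digits printed from compound 1 to compound 4 (within the scatter): the same change on two cores in this assay, a 10-fold lower number (1.00 log units; beyond the scatter) from compound 2 to compound 3 and no change at the digits printed (within the scatter) from compound 1 to compound 4, 10-fold (1.00 log units) apart, beyond the scatter of two such steps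
These four compounds show that the two changes do not simply add up here, but they do not show why, and they give no rule for any other core.

As far as these compounds go, whether an amine or a carboxylic acid in place of the bromo would behave like the nitro remains open. So does the effect of a longer chain in place of the methyl.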